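Carboxy to Phenylcarbamoyl on a Shared Core

The compounds below may be only part of what the source reports. "The series", "measured", "known", "first", "only" and "open" are said of these compounds alone.

In an ADME assay on Vero cells (Chlorocebus sabaeus) for cytotoxicity, with a stated time of 48 h (on this read-out higher numbers stand for lower toxicity in this test and lower numbers for higher toxicity in this test), compound 1 (`CCC(CC)O[C@@H]1C=C(C(=O)O)C[C@H](NC(=O)OC(C)(C)C)[C@H]1NC(C)=O`) gives 750000 nM, level with compound 2 (`CCC(CC)O[C@@H]1C=C(C(=O)Nc2ccccc2OC)C[C@H](NC(=O)OC(C)(C)C)[C@H]1NC(C)=O`) at 753000 nM, the two values lying within the scatter of each other. Compound 3 (`CCC(CC)O[C@@H]1C=C(C(=O)Nc2ccccc2)C[C@H](NC(=O)OC(C)(C)C)[C@H]1NC(C)=O`) has anilino in place of hydroxy on a carbonyl carbon. Among the measured compounds shown here, the one measured step of this kind put (2-methoxyphenyl)amino at that place: a 1.0-fold higher number from compound 1 to compound 2 (0.00 log units; within the scatter). No step beyond the scatter is therefore expected in this assay. The expected change is no change at the digits printed from compound 1 to compound 3 (within the scatter). Compound 3 is estimated at 750000 nM, with an expected range of 350000 nM to 1200000 nM.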

Compound 3, half-maximal cytotoxic concentration: 752000 nM
The estimate for compound 3 lay 1.0-fold (0.00 log units) below the measured number; the range from low to high includes it.
By their numbers in this assay, from the lowest: compounds 1, 3 and 2 (each within the scatter of the next).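

In this assay, replacing hydroxy with anilino gives a 1.0-fold higher number from compound 1 to compound 3 (0.00 log units; within the scatter) at this carbonyl carbon, so a second aromatic amine fits the pattern seen with (2-methoxyphenyl)amino. Methoxy on the aromatic carbon also makes no difference beyond the scatter, with hydrogen in its place giving a 1.0-fold lower number from compound 2 to compound 3 (0.00 log units; within the scatter) across this pair. No measurement on hand accounts for these level values. On these data alone, what remains open is whether a methyl ester or a simple aliphatic amine such as ethylamino at this carbonyl carbon would stay level with these three compounds.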